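The source may hold more compounds than are shown below. What is called first, only, known or untested is meant among the compounds shown, and "the series" means these compounds.

Measured so far in an assay on membranes from CHO cells for displacement of a labelled ligand from adenosine receptor A1 (Homo sapiens), read by scintillation counting, with a stated time of 60 min, tested at 1 uM; a lower number here means less inhibition, a higher number more inhibition at the concentration tested (going by the name of the read-out):

Compound 1, `CCCOC(=O)C1=C(C)N(C)C(=O)NC1c1ccoc1`, gives 1%.
Compound 2, `CC1=C(C(=O)OCC(C)C)C(c2ccoc2)NC(=O)N1C`, gives 4%.
Compound 3, `CCCOC(=O)C1=C(C)N(C)C(=O)NC1c1cccs1`, gives 9%.

All three numbers sit within the usual scatter of one another, so none of them stands out. Compound 2 differs from compound 1 by one change, (methyl in place of hydrogen on a saturated chain carbon bound to two saturated chain carbons), and that change made a step of a number 3 percentage points higher from compound 1 to compound 2 (within the scatter). The two cores differ as well: compound 3 differs from compound 1 by thiophen-2-yl in place of furan-3-yl on a saturated ring carbon, a step of a number 8 percentage points higher from compound 1 to compound 3 (within the scatter).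

Compound 4, `CC1=C(C(=O)OCC(C)C)C(c2cccs2)NC(=O)N1C`, has not yet been measured in this assay. It carries the same change relative to compound 3 that compound 2 carries relative to compound 1: methyl in place of hydrogen on a saturated chain carbon bound to two saturated chain carbons. Because the earlier step of a number 3 percentage points higher from compound 1 to compound 2 (within the scatter) stayed within the scatter, the step from compound 3 to compound 4 is expected to be small too, around a number 3 percentage points higher from compound 3 to compound 4 (within the scatter). Compound 4 is therefore estimated at 12%, likely between 0% and 28%.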

Compound 4, a percentage reported as inhibition, at one concentration (the size of the read-out at that concentration, not a potency): 9%
Compound 4: the middle estimate sits 3 percentage points above what was measured; the measured number falls inside the stated range.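

In this assay, changing propoxy to isobutoxy gives no change at the digits printed from compound 3 to compound 4 (within the scatter), and the comparison with the same change on the other core reads: the same change on two cores in this assay, a number 3 percentage points higher (within the scatter) from compound 1 to compound 2 and no change at the digits printed (within the scatter) from compound 3 to compound 4, 3 percentage points apart, within the scatter of two such steps
Thiophen-2-yl in place of furan-3-yl gives a number 5 percentage points higher from compound 2 to compound 4 (within the scatter), and its comparison reads: the same change on two cores in this assay, a number 8 percentage points higher (within the scatter) from compound 1 to compound 3 and a number 5 percentage points higher (within the scatter) from compound 2 to compound 4, 3 percentage points apart, within the scatter of two such steps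
Within the data shown here, none of these steps rises above the scatter, so the pairs show only that neither change had a clear effect on either core, not that a change with a clear effect would carry over from one core to another.

Still open, as far as these compounds go, is whether a phenyl ring on the saturated ring carbon, or a longer chain in place of isobutoxy, would give a clearly different reading.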